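The compounds below may be only part of what the source reports. "The series", "measured", "known", "first", "only" and "open" are said of these compounds alone.

Compound 1 `O=C(Nc1nc2ccccc2s1)c1cn(-c2ccccc2)nc1-c1ccc(F)cc1` gives 10700 nM in a functional assay on U-87MG ATCC cells for cytotoxicity against U-87 MG (Homo sapiens), read by MTT assay, with a stated time of 72 h; on this read-out higher numbers stand for weaker inhibition and lower numbers for stronger inhibition.
Compound 2 `O=C(Nc1nc2ccc(F)cc2s1)c1cn(-c2ccccc2)nc1-c1ccc(F)cc1` gives 12500 nM in this assay.

Compound 2 holds the higher of the two numbers in this assay, though the gap is only a 1.2-fold higher number from compound 1 to compound 2 (0.07 log units; within the scatter), within the scatter. Compound 3 `COc1ccc2nc(NC(=O)c3cn(-c4ccccc4)nc3-c3ccc(F)cc3)sc2c1` carries methoxy in place of fluoro on an aromatic carbon. Among the compounds with values here, only one measured step bears on this position: the change from compound 1 to compound 2 was a 1.2-fold higher number from compound 1 to compound 2 (0.07 log units; within the scatter), which showed that a swap at this carbon moved the number hardly at all. Within the data shown here, no measured step shows a methoxy at this carbon, so the expectation for compound 3 rests on the small size of that one step. Compound 3 is therefore expected to sit near compound 2 in this assay, a step of a 1.1-fold lower number from compound 2 to compound 3 (0.06 log units; within the scatter), with no direction beyond the scatter. The estimate for compound 3 is 11000 nM, between 4000 nM and 30000 nM.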

Compound 3, half-maximal inhibitory concentration: > 50000 nM
Compound 3 gave a limit, no number; the forecaster's own chance of this, stated with the estimate: 10%; middle value at least 4.5-fold (0.65 log units) away from the limit.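

Compound 3 gave a limit, not a number, in this assay: the limit of > 50000 nM in this assay, at which 1 of the 3 values shown sits.

The aromatic carbon that seemed indifferent when fluoro replaced hydrogen is therefore not indifferent to every group: methoxy in place of fluoro brings an at least 4.0-fold higher number from compound 2 to compound 3 (0.60 log units; beyond the scatter), and methoxy in place of hydrogen brings an at least 4.6-fold higher number from compound 1 to compound 3 (0.66 log units; beyond the scatter). Compound 1 and compound 2 stay within the scatter of each other, so of the three groups shown at this carbon, only methoxy separates from the others, and it does so toward weaker inhibition.

The compounds shown leave open how far the true value of compound 3 lies past its limit. They also leave open whether a methyl, a hydroxyl or an amine at this carbon would behave like methoxy or like fluoro.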